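The source may hold more compounds than are shown below. What is called first, only, known or untested is meant among the compounds shown, and "the series" means these compounds.

Three compounds share one core and differ only in the group carried by the amine nitrogen of the six-membered ring. Compound 1 `Fc1ccc(C(SCCNC2CCN(Cc3ccc(Cl)cc3)CC2)c2ccc(F)cc2)cc1` gives 45.5 nM in an assay on membranes from Cortex for displacement of a labelled ligand from Sigma non-opioid intracellular receptor 1 (Cavia porcellus), read by scintillation counting, with a stated time of 120 min; a higher number here means a weaker inhibitor, a lower number a stronger inhibitor. Compound 2 `O=C(c1ccccc1)N1CCC(NCCSC(c2ccc(F)cc2)c2ccc(F)cc2)CC1` gives 2.03 nM in this assay, and compound 3 `Fc1ccc(C(SCCNC2CCN(Cc3cc4ccccc4o3)CC2)c2ccc(F)cc2)cc1` gives 205 nM in this assay, the highest number of the three. Its nearest neighbour is compound 1, as a 4.5-fold higher number from compound 1 to compound 3 (0.65 log units; beyond the scatter) shows, and its furthest is compound 2, as a 100-fold higher number from compound 2 to compound 3 (2.00 log units; beyond the scatter) shows. Compound 4 `O=C(c1ccc(F)cc1F)N1CCC(NCCSC(c2ccc(F)cc2)c2ccc(F)cc2)CC1` has not yet been measured. It differs from compound 3 in one place: (2,4-difluorophenyl)carbonyl in place of (1-benzofuran-2-yl)methyl on an amine nitrogen in a ring. The step that bears most directly on this change is a 100-fold higher number from compound 2 to compound 3 (2.00 log units; beyond the scatter), a large step in which the benzoyl group gave the far lower number. Compound 4 carries a carbonyl-linked ring of the same kind as compound 2, differing only in the fluorine it bears, so a drop of about the same size is expected, a 68-fold lower number from compound 3 to compound 4 (1.83 log units; beyond the scatter). The estimate for compound 4 is 3 nM, with a range from 1 nM to 12 nM.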

Compound 4, inhibition constant: 20.6 nM
Estimate against measurement, compound 4: 6.9-fold (0.84 log units) below; measured number above the stated range.
By their numbers in this assay, from the lowest: compound 2; then compound 4; then compound 1; then compound 3.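

The carbonyl does not secure the low number by itself: in this assay the ring on it also counts, as a 10-fold higher number from compound 2 to compound 4 (1.01 log units; beyond the scatter) shows for 2,4-difluorophenyl in place of phenyl on the carbonyl carbon. The (2,4-difluorophenyl)carbonyl group still clearly improves on (1-benzofuran-2-yl)methyl, with a 10-fold lower number from compound 3 to compound 4 (1.00 log units; beyond the scatter) on the amine nitrogen in the ring, but its margin over 4-chlorobenzyl is much smaller, though beyond the scatter, with a 2.2-fold lower number from compound 1 to compound 4 (0.34 log units; beyond the scatter) for that exchange. Nothing measured here explains why the two fluorines go with a higher number.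

The compounds shown leave open whether a single fluorine on the phenyl ring would give the same rise. They also leave open how a methoxy group or an amine on that ring, or a pyridine ring in place of the phenyl, would move the number.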